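The source may hold more compounds than are shown below. What is called first, only, known or untested is meant among the compounds shown, and "the series" means these compounds.

Working notes on the series.

Among the measured compounds shown here, compound 1, `Nc1cc(N)c2nc(-c3ccccc3)c(NCc3ccc(Cl)c(Cl)c3)nc2c1`, is the only member of the set for which a functional assay on SK-OV-3 cells (Homo sapiens) for inhibition, read by sulforhodamine B assay, with a stated time of 48 h (a lower number here means that less compound is tolerated, a higher number that more compound is tolerated), returns a number: compound 1 gives 69200 nM. The other two measured members carry only limits. Compound 2, `CCOC(=O)[C@H](CCC(=O)O)NC(=O)c1ccc(Sc2nc3cc(N)cc(N)c3nc2-c2ccccc2)cc1`, reaches only the limit of < 100000 nM in this assay. Compound 3, `CCOC(=O)[C@H](CCC(=O)O)NC(=O)c1ccc(Oc2nc3cc(N)cc(N)c3nc2-c2ccccc2)cc1`, likewise stops at the limit of < 100000 nM in this assay. So the set offers one number and two limits, and the limit of < 100000 nM in this assay, at which 2 of the 3 values shown sit, is the main feature of the data, with compound 1 the single point that can be followed.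

Compound 4, `COc1ccc(CNc2nc3cc(N)cc(N)c3nc2-c2ccccc2)cc1`, keeps the core of compound 1 and alters the side chain on the aromatic amine: 4-methoxyphenyl in place of 3,4-dichlorophenyl on a saturated chain carbon bound to a nitrogen on an aromatic ring. For the measured compounds named here, no measured pair in the set isolates this kind of change, so its size in this assay cannot be read from the data; the step from compound 1 to compound 4 is therefore taken as modest, possibly toward a higher value, and close to the usual scatter rather than clearly beyond it.

The step of a 1.3-fold higher number from compound 1 to compound 4 (0.11 log units; within the scatter) is the expectation behind the estimate. Compound 4 is expected to give about 90000 nM in this assay, with a range from 40000 nM to 200000 nM, and a real chance that only a limit is returned.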

Compound 4, concentration lethal to 50% of the cells: < 100000 nM
Compound 4 gave a limit, no number; the forecaster's own chance of this, stated with the estimate: 40%; the middle value lies beyond the limit too.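

Among the compounds shown here, compound 4 returns only a limit in this assay, so no step from compound 1 to compound 4 can be read, and the effect of 4-methoxyphenyl in place of 3,4-dichlorophenyl has no size. The compounds shown leave open whether any side-chain change moves the value in this assay, with compound 1 the only number against: the limit of < 100000 nM in this assay, at which 3 of the 4 values shown sit.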